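A few compounds are considered here, and "the series" means these few. Any claim that something is new, unique, unknown or untested is made for them only; others in the source may bear on it.

Series values in a functional assay on BC1 cells (Homo sapiens) for cytotoxicity, read by sulforhodamine B assay, with a stated time of 72 h; a lower number here means that less compound is needed, a higher number that more compound is needed for the effect:

- Compound 1 `CCCC[C@H](OC(C)=O)[C@@H](O)[C@H](O)[C@@H]1OC(=O)C=C[C@@H]1OC(C)=O`: 9.9 ug/mL
- Compound 2 `CCCC[C@@H](/C=C\[C@@H]1OC(=O)C[C@@H](OC)[C@@H]1O)OC(C)=O`: > 20 ug/mL
- Compound 3 `CCCC[C@H](OC(C)=O)[C@@H](OC(C)=O)[C@H](OC(C)=O)[C@H]1CC=CC(=O)O1`: 2.8 ug/mL

Going by the values given here, the entry for compound 2 is a limit of the assay and not a number, so only two numerical values are available for comparison. the limit of > 20 ug/mL in this assay, at which 1 of the 3 values shown sits, applies to that one compound.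

Compound 3 holds the lower of the two numbers at 2.8 ug/mL, while compound 1 gives 9.9 ug/mL, and this gap lies beyond the usual scatter.

The next compound to be tested is compound 4 `CCCC[C@H](OC(C)=O)[C@@H](OC(C)=O)[C@H](OC(C)=O)[C@@H]1OC(=O)C=C[C@@H]1OC(C)=O`. It departs from compound 3 through acetoxy in place of hydrogen on a saturated ring carbon.

Among the compounds with values here, no measured pair isolates this change, so the expectation is only loosely anchored. It rests on compound 3 at 2.8 ug/mL as the starting point and on compound 1 at 9.9 ug/mL as the nearest numerical value. In this assay, no step beyond the scatter is expected, though a drift to a higher number remains possible. The expected change is a 1.3-fold higher number from compound 3 to compound 4 (0.10 log units; within the scatter). The estimate for compound 4 is 3.5 ug/mL, with an expected range of 1.2 ug/mL to 10 ug/mL.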

Compound 4, concentration for half-maximal effect: 7 ug/mL
Compound 4: middle estimate off by 2.0-fold (0.30 log units), on the low side, within the range that was stated.
By their numbers in this assay, from the lowest: compound 3; then compounds 4 and 1 (each within the scatter of the next). At a limit, above all of these: compound 2.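

In this assay the pair gives the series its first reading of a change in a single place: acetoxy in place of hydrogen on a saturated ring carbon, two ring bonds from the ring oxygen, gives a 2.5-fold higher number from compound 3 to compound 4 (0.40 log units; beyond the scatter). The step is modest but lies beyond the scatter, so this ring carbon is not a silent position for the read-out, and compound 4 still gives a number and not a limit, so the added acetoxy leaves the cytotoxic effect in place. Nothing measured for these compounds bears on what lies behind the step.

A single pair at a single position cannot separate an effect of acetoxy as such from an effect of any group replacing hydrogen on this ring carbon. On these data alone, an amino group or a benzoyloxy group at the same place would show whether the higher number holds beyond acetoxy, and whether the step carries over to cell lines other than this one also stays open.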